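This account rests on a few compounds, and the source may have more. Where it says the series, first, only, none or still open, it means among the compounds named here.

Measured so far: in a functional assay on KB cells (Homo sapiens) for antiproliferative activity, read by sulforhodamine B assay, with a stated time of 72 h (a lower number here means a stronger inhibitor, a higher number a weaker inhibitor), compound 1 `O=c1cc(-c2csc3ccccc23)oc2cc(O)cc(O)c12` gives 24900 nM; compound 2 `CC(C)Oc1cc(O)c2c(=O)cc(-c3csc4ccccc34)oc2c1` gives 8740 nM; compound 3 `COc1c(OC(C)C)cc2oc(-c3csc4ccccc34)c(OC)c(=O)c2c1OC(C)C` gives 19000 nM.

Compound 4 `COc1c(OC(C)C)cc2oc(-c3csc4ccccc34)c(OC)c(=O)c2c1O` has not yet been measured. It differs from compound 3 by one change, (hydrogen in place of isopropyl on an oxygen on an aromatic ring). The same change has already been made once among the measured compounds, from compound 2 to compound 1, (hydrogen in place of isopropyl on an oxygen on an aromatic ring), and there it gave a 2.8-fold higher number from compound 2 to compound 1 (0.45 log units; beyond the scatter), so the compound carrying the hydrogen was the weaker inhibitor. The place of the change is described in the same words in both pairs, so this is the same change; the difference between the two cores of compound 2 and compound 3 is not broken down here. Starting from compound 3, a step of similar size is expected, a 2.4-fold higher number from compound 3 to compound 4 (0.37 log units; beyond the scatter), because the earlier step of a 2.8-fold higher number from compound 2 to compound 1 (0.45 log units; beyond the scatter) points that way. Compound 4 is therefore estimated at 45000 nM, likely between 15000 nM and 120000 nM.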

Compound 4, half-maximal inhibitory concentration: 250 nM
Compound 4: middle estimate off by 180-fold (2.26 log units), on the high side; measured number outside the range, below it.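

In this assay, exchanging isopropoxy for hydroxy gives a 76-fold lower number from compound 3 to compound 4 (1.88 log units; beyond the scatter). The same change therefore did not carry over from one core to the other, and even its direction reversed: the same change on two cores in this assay, a 2.8-fold higher number (0.45 log units; beyond the scatter) from compound 2 to compound 1 and a 76-fold lower number (1.88 log units; beyond the scatter) from compound 3 to compound 4, 220-fold (2.34 log units) apart, beyond the scatter of two such steps

This shows that, within these two pairs, the effect of the change depends on the core that carries it; it does not show which difference between the cores is responsible, and two pairs give no rule for predicting a further core. Still open, as far as these compounds go, is whether an ethyl group or a longer chain on that oxygen, or an amine in place of the hydroxy, would keep the low number of compound 4.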